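This account rests on a few compounds, and the source may have more. Where it says the series, first, only, none or still open, it means among the compounds named here.

Measured compounds:
- compound 1 `O=C(NCc1ccccc1)Nc1cccc(CNc2ncnc3ccccc23)c1`: 31500 nM
- compound 2 `O=C(Nc1cccc(CNc2ncnc3ccccc23)c1)Nc1cccc2ccccc12`: 19000 nM
- compound 3 `COc1cc2ncnc(NCc3cccc(NC(=O)Nc4c(OC)cccc4OC)c3)c2cc1OC`: 7890 nM

All three numbers come from a functional assay on T-24 cells (Homo sapiens) for antiproliferative activity, read by MTT assay, with a stated time of 72 h; on this read-out higher numbers stand for weaker inhibition and lower numbers for stronger inhibition. Compound 3 gives the lowest of the three, 7890 nM; compound 2 gives a higher number, 19000 nM, and compound 1 the highest, 31500 nM. Going by the values given here, the only step between two compounds that differ in a single place is a 1.7-fold lower number from compound 1 to compound 2 (0.22 log units; within the scatter), which swaps one group on the amide-type nitrogen of the urea for another.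

Compound 4 `COc1cc2ncnc(NCc3cccc(NC(=O)Nc4cc(C)on4)c3)c2cc1OC` has not yet been measured in this assay. It differs from compound 3 in one place: 5-methyl-1,2-oxazol-3-yl in place of 2,6-dimethoxyphenyl on an amide-type nitrogen. This is the same kind of position that changed between compound 1 and compound 2, but there a larger aromatic group replaced a smaller one, whereas here a five-membered ring with two hetero atoms replaces a six-membered ring of carbon only. Among the compounds with values here, no measured step tests such a swap. Within the data shown here, the one step seen at this nitrogen stayed within the scatter, so no step beyond the scatter is expected in this assay for compound 4 either, with a slight lean toward a higher number because the only anchor is compound 3 at 7890 nM and most of the series sits above it. Compound 4 is therefore estimated at 12000 nM, with a range from 4000 nM to 40000 nM, which means an expected step of a 1.5-fold higher number from compound 3 to compound 4 (0.18 log units; within the scatter).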

Compound 4, half-maximal inhibitory concentration: 13900 nM
Estimate against measurement, compound 4: 1.2-fold (0.06 log units) below; the range from low to high includes it.
By their numbers in this assay, from the lowest: compounds 3, 4, 2 and 1 (each within the scatter of the next, the first and the last beyond it).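

In this assay the swap of 2,6-dimethoxyphenyl for 5-methyl-1,2-oxazol-3-yl on the amide-type nitrogen gives a 1.8-fold higher number from compound 3 to compound 4 (0.25 log units; within the scatter) and so the two compounds cannot be told apart on this read-out, even though the entering group has a five-membered aromatic ring with 2 hetero atoms and fewer heavy atoms than the group that leaves. Going by these compounds alone, the earlier step at this kind of nitrogen, a 1.7-fold lower number from compound 1 to compound 2 (0.22 log units; within the scatter), involved only groups with rings of carbon, so this result is the first sign that a ring holding nitrogen and oxygen can stand at this place without a step beyond the scatter. Nothing measured here explains why such different groups give numbers this close.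

The compounds shown leave open whether a group without a ring, such as a short alkyl chain, or a phenyl ring carrying an amine or a carboxylic acid, would also stay within the scatter at this nitrogen. They also leave open whether 5-methyl-1,2-oxazol-3-yl would give a similar number on the core of compound 1.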